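This account rests on a few compounds, and the source may have more. Where it says the series, first, only, none or still open, it means among the compounds named here.

Measured so far:
compound 1, `CCOC(=O)c1oc2cc(OCc3ccccc3)cc(OCc3ccccc3)c2c1C`: > 72000 nM
compound 2, `CCOC(=O)c1oc2cc(O)cc(O)c2c1C`: 68600 nM
compound 3, `CCOC(=O)c1oc2c(C(N)=O)c(OCc3ccccc3)cc(OCc3ccccc3)c2c1C`: < 7200 nM

In a functional assay on A549 cells (Homo sapiens) for cytotoxicity, read by MTT assay (a lower number here means a stronger inhibitor, a higher number a weaker inhibitor), compound 2 gives 68600 nM. For compound 1 the value of > 72000 nM is a limit of the assay, not a number. For compound 3 the value of < 7200 nM is likewise a limit. Between these two lies the only measured step, an at least 10-fold lower number from compound 1 to compound 3 (1.00 log units; beyond the scatter), made by carbamoyl in place of hydrogen on an aromatic carbon. Its size is known only as a bound because the limit of < 7200 nM in this assay, at which 1 of the 3 values shown sits, and the limit of > 72000 nM in this assay, at which 1 of the 3 values shown sits, mark both of its ends. How the core of compound 1 differs from the core of compound 2 is not broken down here. Compound 4, `CCOC(=O)c1oc2c(C(N)=O)c(O)cc(O)c2c1C`, has not yet been measured in this assay; it differs from compound 2 by carbamoyl in place of hydrogen on an aromatic carbon. This is the same kind of change, though the surroundings differ: in compound 3 the carbamoyl sits ortho to a benzyloxy group and para to a benzyloxy group, whereas in compound 4 it sits ortho to a hydroxy group and para to a hydroxy group. Resting on an at least 10-fold lower number from compound 1 to compound 3 (1.00 log units; beyond the scatter), a step of similar direction is expected for compound 4, an 11-fold lower number from compound 2 to compound 4 (1.06 log units; beyond the scatter). Compound 4 is therefore estimated at 6000 nM, expected to fall between 1500 nM and 25000 nM.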

Compound 4, half-maximal inhibitory concentration: 24000 nM
The estimate for compound 4 lay 4.0-fold (0.60 log units) below the measured number; measured number inside the range.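

On the core of compound 2, carbamoyl in place of hydrogen gives a 2.9-fold lower number from compound 2 to compound 4 (0.46 log units; beyond the scatter) in this assay, which is the same direction as on the core of compound 1, so the direction of the change carries over between these two cores. Its size does not carry over, as the two steps differ: the same change on two cores in this assay, an at least 10-fold lower number (1.00 log units; beyond the scatter) from compound 1 to compound 3 and a 2.9-fold lower number (0.46 log units; beyond the scatter) from compound 2 to compound 4, at least 3.4-fold (0.54 log units) apart, beyond the scatter of two such steps

From the compounds shown here alone, both ends of the earlier step are limits of the assay, not numbers, so its true size is unknown, and two pairs cannot show what in the cores sets the gap between the steps.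

The compounds shown leave open whether another group on the same aromatic carbon, such as a carboxylic acid or an amine, would lower the number as carbamoyl does. Also open, going by these compounds, is how the carbamoyl step would turn out on a core with one hydroxy group and one benzyloxy group, which would help to separate the two cores compared here.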